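From 2-chlorophenyl to 4-chlorophenyl: no large step expected

The source may hold more compounds than are shown below. What is called first, only, known or untested is meant among the compounds shown, and "the series" means these compounds.

In a functional assay on the whole organism (strain Kunming) with Mus musculus as the target, in the formalin test, with a stated time of 0.5 h (on this read-out lower numbers stand for an effect already at smaller amounts and higher numbers for an effect only at larger amounts of compound), compound 3 (`COc1cc(OC)c(OC)cc1/C=C/COC(=O)/C=C/c1ccccc1Cl`) gives 101 mg/kg. This lies within the scatter of compound 1 (`COc1cc(OC)c(OC)cc1/C=C/COC(=O)/C=C/c1cccc(Br)c1`) at 113 mg/kg and of compound 2 (`COc1cc(OC)c(OC)cc1/C=C/COC(=O)/C=C/c1ccc(OC)c(OC)c1OC`) at 78.4 mg/kg. Compound 4 (`COc1cc(OC)c(OC)cc1/C=C/COC(=O)/C=C/c1ccc(Cl)cc1`) differs from compound 3 by 4-chlorophenyl in place of 2-chlorophenyl on a double-bonded chain carbon bound to a double-bonded chain carbon, placing 4-chlorophenyl where 2-chlorophenyl stood. Within the data shown here, the one measured step at this place, a 1.1-fold lower number from compound 1 to compound 3 (0.05 log units; within the scatter), exchanges 3-bromophenyl for 2-chlorophenyl and stays within the scatter. Among the measured compounds shown here, no measurement yet shows what 4-chlorophenyl itself does. The expected change, a 1.1-fold lower number from compound 3 to compound 4 (0.03 log units; within the scatter), is therefore estimated to remain within the scatter, with no direction favoured. Compound 4 is expected at 95 mg/kg, with an estimated range of 55 mg/kg to 165 mg/kg.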

Compound 4, dose for half-maximal effect: 108 mg/kg
The estimate for compound 4 lay 1.1-fold (0.06 log units) below the measured number, within the range that was stated.
By their numbers in this assay, from the lowest: compounds 2, 3, 4 and 1 (each within the scatter of the next).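

In this assay, 4-chlorophenyl in place of 2-chlorophenyl stays within the scatter (a 1.1-fold higher number from compound 3 to compound 4 (0.03 log units; within the scatter)), so this first measurement of 4-chlorophenyl does not tell the two chlorophenyl groups apart at this place. The exchange of 3-bromophenyl for 4-chlorophenyl also stays within the scatter (a 1.0-fold lower number from compound 1 to compound 4 (0.02 log units; within the scatter)), and the three halogen-bearing phenyl groups shown cannot be told apart in this read-out. No evidence is available that bears on this result. The compounds shown leave open what a phenyl group carrying an amine or a carboxylic acid would do at this place.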